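The source may hold more compounds than are shown below. What is called first, only, known or untested is meant among the compounds shown, and "the series" means these compounds.

Of the compounds shown here, three from this series have been tested in a functional assay on DU-145 cells (Homo sapiens) for inhibition, read by trypan blue exclusion, with a stated time of 96 h; on this read-out lower numbers stand for stronger inhibition of growth and higher numbers for weaker inhibition of growth. Compound 1 `Cc1cc(C)cc(/C=C(/SCc2ccc(F)cc2)C(=O)c2ccc(Br)cc2)c1` and compound 2 `COc1ccccc1/C=C(/SCc1ccc(F)cc1)C(=O)c1ccc(Br)cc1` share one core; in this assay compound 1 gives 10000 nM and compound 2 gives 10000 nM. Compound 3 `COc1ccccc1/C=C(\C(=O)c1ccc(Cl)cc1)S(=O)(=O)Cc1ccc(Cl)cc1` is built on a second core, and in this assay compound 3 gives 25000 nM, the highest of the three numbers, with its gap to each of the other two lying beyond the usual scatter. The difference between the two cores is not broken down here.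

Within the first core, the move from compound 2 to compound 1 is a single change, (3,5-dimethylphenyl in place of 2-methoxyphenyl on a double-bonded chain carbon bound to a double-bonded chain carbon). Its effect is no change at the digits printed from compound 2 to compound 1 (within the scatter).

Compound 4 `Cc1cc(C)cc(/C=C(\C(=O)c2ccc(Cl)cc2)S(=O)(=O)Cc2ccc(Cl)cc2)c1` has not yet been measured. It stands to compound 3 exactly as compound 1 stands to compound 2: the change is 3,5-dimethylphenyl in place of 2-methoxyphenyl on a double-bonded chain carbon bound to a double-bonded chain carbon, at the same place and in the same words, so it is the same change applied to the second core. Within the data shown here, the only precedent for this change is the flat step recorded from compound 2 to compound 1, and nothing among the measured compounds suggests the second core would answer it differently. On that basis compound 4 is expected to sit close to compound 3, with the estimated step being no change at the digits printed from compound 3 to compound 4 (within the scatter). The estimate for compound 4 in this assay is 25000 nM, with a likely range from 12000 nM to 50000 nM.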

Compound 4, concentration for 50% growth inhibition: 1000 nM
Beside the measured number, compound 4's estimate is 25-fold (1.40 log units) above it; measured number outside the range, below it.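

In this assay, the swap of 2-methoxyphenyl for 3,5-dimethylphenyl on a double-bonded chain carbon bound to a double-bonded chain carbon does not carry over from one core to the other with the same size of effect: the same change on two cores in this assay, no change at the digits printed (within the scatter) from compound 2 to compound 1 and a 25-fold lower number (1.40 log units; beyond the scatter) from compound 3 to compound 4, 25-fold (1.40 log units) apart, beyond the scatter of two such steps. On the core of compound 3 the same change gives a 25-fold lower number from compound 3 to compound 4 (1.40 log units; beyond the scatter), so in this series the flat result on the core of compound 1 was no reliable guide to what the change does on the second core. What this does not show is which of the several differences between the two cores separates the two outcomes, why they part, or how the change would behave on any further core, as the comparison rests on just two matched pairs in a single assay.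

The compounds shown leave open whether both methyl groups of the 3,5-dimethylphenyl ring are needed on the core of compound 3, or whether a phenyl ring with a single methyl group would serve as well as compound 4 does. They also leave open how that core would respond if an amine or a carboxylic acid were carried on this ring in place of the methyl groups.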